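The source may report more compounds than this note shows. Statements on the series, on what has been measured and on what is new or still open speak of the compounds shown alone.

Measured in an ADME assay on the whole organism (Mus musculus, strain CD-1) for pharmacokinetics, at a dose of 10 mg/kg by the oral route; a lower number here means that a smaller share of the oral dose reaches the circulation, a higher number that a larger share of the oral dose reaches the circulation:
- compound 1 `COc1cc([C@](O)(CCN(C)C)[C@@H](c2cc3cc(Br)ccc3nc2OC)c2cccc(OC)c2F)cc(OC(F)F)n1`: 83%
- compound 2 `COc1cc([C@](O)(CCN(C)C)[C@@H](c2cc3cc(Br)ccc3nc2OC)c2ccnc(OC)c2OC)cc(OC(F)F)n1`: 50%
- compound 3 `COc1cc([C@](O)(CCN(C)C)[C@@H](c2cc3cc(C#N)ccc3nc2OC)c2ccnc(OC)c2OC)cc(OC(F)F)n1`: 43%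

Compound 1 stands highest of the three in this assay, with compound 2 and compound 3 both beyond the scatter beneath it. Compound 4 `CCSc1cc([C@](O)(CCN(C)C)[C@@H](c2cc3cc(Br)ccc3nc2OC)c2cccc(OC)c2F)cc(SCC)n1` differs from compound 1 in one place: a group of 12 heavy atoms (9 carbon, 1 nitrogen, 2 sulfur; one six-membered aromatic ring with 1 hetero atom) in place of a group of 12 heavy atoms (7 carbon, 1 nitrogen, 2 oxygen, 2 fluorine; one six-membered aromatic ring with 1 hetero atom), on a saturated chain carbon bound to an oxygen on a saturated carbon and two saturated chain carbons.

Neither measured step touches that place, so the evidence is only indirect. The replacement elsewhere gave a number 33 percentage points lower from compound 1 to compound 2 (beyond the scatter), which was large, while the other gave a number 7 percentage points lower from compound 2 to compound 3 (within the scatter). These show that a single replacement can cost much from the top value, so a sizeable fall is expected, though its size is uncertain.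

The expected step is a number 28 percentage points lower from compound 1 to compound 4 (beyond the scatter).

For compound 4 the estimated value is 55%, within an expected range of 25% to 80%.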

Compound 4, oral bioavailability: 25%
The estimate for compound 4 lay 30 percentage points above the measured number; low and high end bracket the measured number.
By their numbers in this assay, from the lowest: compound 4; then compounds 3 and 2 (each within the scatter of the next); then compound 1.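

In this assay, for the compounds shown here, this is the first direct reading at the saturated chain carbon, and the place proves sensitive: the replacement gives a number 58 percentage points lower from compound 1 to compound 4 (beyond the scatter). The fall comes although both groups have the same counts of heavy atoms, hydrogen-bond donors and acceptors, and neither carries a net charge. Nothing measured here accounts for it.

Both substituents on the ring change together, so the compounds shown do not tell which of them carries the loss. Also open, as far as these compounds go, is how a ring bearing one ethylthio group beside one methoxy group, or an amine, would behave.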